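The source may hold more compounds than are shown below. What is called first, only, known or untested is meant among the compounds shown, and "the series" means these compounds.

Compound 1 `COc1cc2c(Oc3ccc(NC(=O)c4cc(-c5ccccc5)nc5ccccc45)cc3F)ccnc2cc1OCCCN1CCCCC1` gives 530 nM in a functional assay on HT-29 cells (Homo sapiens) for cytotoxicity, read by MTT assay, with a stated time of 72 h; on this read-out lower numbers stand for stronger inhibition and higher numbers for weaker inhibition. Compound 2 `COc1cc2c(Oc3ccc(NC(=O)c4cc(-c5ccc(F)cc5)nc5ccccc45)cc3F)ccnc2cc1OCCCN1CCCCC1` carries fluoro in place of hydrogen on an aromatic carbon and gives 130 nM, the step being a 4.1-fold lower number from compound 1 to compound 2 (0.61 log units; beyond the scatter). Compound 3 `COc1cc2c(Oc3ccc(NC(=O)c4cc(-c5cccc(Cl)c5)nc5ccccc45)cc3F)ccnc2cc1OCCCN1CCC(C)CC1` gives 100 nM; the difference between its core and the core of compound 1 is not broken down here. Compound 4 `COc1cc2c(Oc3ccc(NC(=O)c4cc(-c5cccc(Cl)c5)nc5ccc(F)cc45)cc3F)ccnc2cc1OCCCN1CCC(C)CC1` is not yet measured; it differs from compound 3 by fluoro in place of hydrogen on an aromatic carbon. This is the same kind of change as that between compound 1 and compound 2, but the place differs: here the ring is part of a fused or bridged system of two rings, meta to a fused ring and para to a fused ring, whereas in compound 2 the fluoro sits para to a large group. In this assay the expected step is a 1.4-fold lower number from compound 3 to compound 4 (0.15 log units; within the scatter), smaller than the earlier one, because a 4.1-fold lower number from compound 1 to compound 2 (0.61 log units; beyond the scatter) arose at a different place and need not carry over. Compound 4 is estimated at 70 nM, within 30 nM to 200 nM.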

Compound 4, half-maximal inhibitory concentration: 92 nM
For compound 4 the middle estimate is 1.3-fold (0.12 log units) below the measured one; low and high end bracket the measured number.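

In this assay, fluoro in place of hydrogen on an aromatic carbon gives a 1.1-fold lower number from compound 3 to compound 4 (0.04 log units; within the scatter) on the core of compound 3. The size of the step therefore does not carry over unchanged from one core to the other: the same change on two cores in this assay, a 4.1-fold lower number (0.61 log units; beyond the scatter) from compound 1 to compound 2 and a 1.1-fold lower number (0.04 log units; within the scatter) from compound 3 to compound 4, 3.8-fold (0.57 log units) apart, beyond the scatter of two such steps. The fluoro also sits at a different place in each pair, so these two steps do not show whether the place or the rest of the core sets the size, and they give no rule for the series.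

Still open, going by these compounds, is what fluoro would give at the place it holds in compound 4 on the core of compound 1. Also open, on these data alone, is what chloro or methoxy would give at that same place.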